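Methyl in Place of Fluoro on the Triazole Aryl Group

The compounds below may be only part of what the source reports. "The series", "measured", "known", "first", "only" and "open" are said of these compounds alone.

Measured so far:
Compound 1, `C=C1C[C@]23C[C@@]1(O)CC[C@H]2c1ccc(OS(=O)(=O)c2ccc(C)cc2)c(C)c1[C@@H]3Cn1cc(-c2ccc(C)cc2)nn1`: in a functional assay on HL-60 cells (Homo sapiens) for cytotoxicity, read by MTT assay, with a stated time of 4 days (a higher number here means a weaker inhibitor, a lower number a stronger inhibitor), compound 1 reaches only the assay limit > 20000 nM.
Compound 2, `C=C1C[C@]23C[C@@]1(O)CC[C@H]2c1ccc(OS(=O)(=O)c2ccc(C)cc2)c(C)c1[C@@H]3Cn1cc(-c2ccc(F)cc2)nn1`: in this assay compound 2 also reaches only the assay limit > 20000 nM.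
Compound 3, `C=C1C(=O)[C@]23C[C@@]1(O)CC[C@H]2c1ccc(OS(=O)(=O)c2ccc(C)cc2)c(C)c1[C@@H]3Cn1cc(-c2ccc(F)cc2)nn1`: in this assay compound 3 gives 1290 nM.

Compounds 1 and 2 share one core and differ in a single change, (methyl in place of fluoro on an aromatic carbon). The step that the two limits leave unreadable from compound 2 to compound 1 cannot be read because both values sit at the limit of > 20000 nM in this assay, at which 2 of the 3 values shown sit. Compound 3 carries a carbonyl in its core; how that core differs from the core of compound 2 is not broken down here.

Compound 4, `C=C1C(=O)[C@]23C[C@@]1(O)CC[C@H]2c1ccc(OS(=O)(=O)c2ccc(C)cc2)c(C)c1[C@@H]3Cn1cc(-c2ccc(C)cc2)nn1`, is not yet measured. It stands to compound 3 exactly as compound 1 stands to compound 2, through the same change, (methyl in place of fluoro on an aromatic carbon), at the same place. The earlier step gives no size, so the expected step of a 1.2-fold higher number from compound 3 to compound 4 (0.07 log units; within the scatter) in this assay rests only on compound 3 and its value 1290 nM, with a shift expected to stay within the usual scatter. Compound 4 is therefore expected to give about 1500 nM. The estimate for compound 4 is taken to lie between 500 nM and 5000 nM.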

Compound 4, half-maximal inhibitory concentration: 1110 nM
The estimate for compound 4 lay 1.4-fold (0.13 log units) above the measured number; low and high end bracket the measured number.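

In the core that carries the carbonyl, going from 4-fluorophenyl to 4-methylphenyl gives a 1.2-fold lower number from compound 3 to compound 4 (0.07 log units; within the scatter) in this assay, so within this one pair the change cannot be told apart from ordinary assay noise. The same change on the core of compound 1 and compound 2 cannot be read, because both compounds give an assay limit and not a number: the limit of > 20000 nM in this assay, at which 2 of the 4 values shown sit. The series therefore offers only one readable pair and no true comparison between cores, so it does not show that the change behaves alike on both, although nothing shown speaks against that.

The compounds shown carry only fluoro or methyl at this place, which leaves open whether an amine, a carboxylic acid or a longer chain there would shift the number beyond the scatter. Also open, from the compounds shown here alone, is whether any such group would bring a compound with the core of compound 1 off the limit.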